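Fluoro to trifluoromethyl in a series sitting at its limit

The source may hold more compounds than are shown below. What is called first, only, known or untested is meant among the compounds shown, and "the series" means these compounds.

In a functional assay on MDA-MB-231 cells (Homo sapiens) for cytotoxicity, read by MTT assay, with a stated time of 48 h (on this read-out lower numbers stand for stronger inhibition and higher numbers for weaker inhibition), compound 1 `COc1ccc(N/C=C\C(=O)c2nc(-c3ccc(F)cc3)n3ccccc23)cc1` gives > 30000 nM, which is a limit and not a number. Compound 2 `COc1ccc(N/C=C\C(=O)c2nc(-c3ccc(F)cc3)n3ccccc23)cc1OC` gives > 30000 nM, also a limit. Compound 3 `Cc1cc2cc(N/C=C\C(=O)c3nc(-c4ccc(F)cc4)n4ccccc34)ccc2[nH]1` gives > 30000 nM, again a limit. Among the compounds with values here, the series so far therefore sits at the limit of > 30000 nM in this assay, at which 3 of the 3 values shown sit, and compound 1 offers no numerical starting point.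

Compound 4 `COc1ccc(N/C=C\C(=O)c2nc(-c3ccc(C(F)(F)F)cc3)n3ccccc23)cc1` carries trifluoromethyl in place of fluoro on an aromatic carbon, para to a large group: trifluoromethyl in place of fluoro on an aromatic carbon.

Three measured steps are available. Within the data shown here, the first is a step that the two limits leave unreadable from compound 1 to compound 2. The second is a step that the two limits leave unreadable from compound 1 to compound 3. The third is a step that the two limits leave unreadable from compound 2 to compound 3. None of them changes the fluoro group and none has a readable size, so they give no direct measure for this change. They show only that three variations of the group on the amine nitrogen all remain at the limit.

Compound 4 is expected most likely to remain at a limit as well. Any expected an at least 1.2-fold lower number from compound 1 to compound 4 (0.07 log units; that floor lies within the scatter) would be modest, toward stronger inhibition, and may prove unreadable. For compound 4 the estimate is 25000 nM, with an expected range from 7000 nM to 50000 nM.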

Compound 4, half-maximal inhibitory concentration: > 30000 nM
Compound 4: a limit, no number; the forecaster's own chance of this, stated with the estimate: 65%; middle value at least 1.2-fold (0.07 log units) away from the limit.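

In this assay compound 4 gives > 30000 nM, a limit and not a number. Within the data shown here, compound 1 is also at a limit, so no step from fluoro to trifluoromethyl can be read between compound 1 and compound 4. The series stays where it was: the limit of > 30000 nM in this assay, at which 4 of the 4 values shown sit.

On these data alone, whether fluoro and trifluoromethyl differ at all on this read-out remains open.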